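Bicyclic aryl in place of pyridinyl on the methylidene carbon

A few compounds are considered here, and "the series" means these few. Any claim that something is new, unique, unknown or untested is made for them only; others in the source may bear on it.

Measured compounds:
compound 1 `CCOC(=O)C1=C(Nc2ccccc2)S/C(=C\c2ccc(Br)c(O)c2)C1=O` — 16.4%
compound 2 `CCOC(=O)C1=C(Nc2ccccc2)S/C(=C\c2cccnc2)C1=O` — < 10%

In a functional assay on MCF7 cells (Homo sapiens) for inhibition, read by MTT assay, with a stated time of 72 h, tested at 10 uM (a lower number here means less inhibition, a higher number more inhibition at the concentration tested (going by the name of the read-out)), compound 1 gives 16.4%. Compound 2 reaches only the limit of this assay, < 10%, which is a limit and not a number (the limit of < 10% in this assay, at which 1 of the 2 values shown sits). Among the measured compounds shown here, the single measured step, a number at least 6.4 percentage points lower from compound 1 to compound 2 (that floor lies within the scatter), carries a floor that lies within the scatter, so it says little about the effect of changing the group at this position.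

Compound 3 `CCOC(=O)C1=C(Nc2ccccc2)S/C(=C\c2cc3ccncc3[nH]2)C1=O` has not yet been measured. It differs from compound 2 in that (a group of 9 heavy atoms (7 carbon, 2 nitrogen; one five-membered aromatic ring with 1 hetero atom, one six-membered aromatic ring with 1 hetero atom) in place of a group of 6 heavy atoms (5 carbon, 1 nitrogen; one six-membered aromatic ring with 1 hetero atom), on a double-bonded chain carbon bound to a double-bonded ring carbon). For the measured compounds named here, no measured step involves the entering group. Compound 2 stands at the limit, and both measured compounds read low in this assay. The step of a number at least 2 percentage points higher from compound 2 to compound 3 (that floor lies within the scatter) is therefore expected to be none beyond the scatter, with a fair chance that the assay again reports only a limit. Compound 3 is estimated at 12%, range 2% to 30%.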

Compound 3, a percentage reported as inhibition, at one concentration (the size of the read-out at that concentration, not a potency): 18.2%
For compound 3 the middle estimate is 6.2 percentage points below the measured one; measured number inside the range.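

Against the 4-bromo-3-hydroxyphenyl group, the new bicyclic group in this assay gives a number 1.8 percentage points higher from compound 1 to compound 3 (within the scatter), so at this place on the double-bonded chain carbon these two quite different groups cannot be told apart. Against pyridin-3-yl the reading is a number at least 8.2 percentage points higher from compound 2 to compound 3 (that floor lies within the scatter), so the larger group with its added hydrogen-bond donor gives no gain that can be separated from noise. Compound 2 remains a limit and not a number: the limit of < 10% in this assay, at which 1 of the 3 values shown sits.

Still open, from the compounds shown here alone, is whether any group at this place can move the reading beyond the scatter, for instance an aryl group carrying a carboxylic acid or a primary amine. Among the compounds shown here, also open is what replacing the ethyl ester or the phenylamino group of the shared core would do, and these single-concentration readings give no potency for any compound.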